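The source may hold more compounds than are shown below. What is called first, only, known or untested is meant among the compounds shown, and "the series" means these compounds.

Working notes on the series in a functional assay on A2780 cells (Homo sapiens) for antiproliferative activity, read by fluorescence, with a stated time of 72 h; on this read-out lower numbers stand for stronger inhibition and higher numbers for weaker inhibition. Compound 1 `CN1CCC(C(=O)N2Cc3c(NC(=O)c4ccc5ccccc5c4)n[nH]c3C2(C)C)CC1` gives 270 nM, compound 2 `CN1CCC(C(=O)N2Cc3c(NC(=O)Nc4cccc(F)c4)n[nH]c3C2(C)C)CC1` gives 350 nM, and compound 3 `CN1CCC(C(=O)N2Cc3c(NC(=O)c4ccncc4)n[nH]c3C2(C)C)CC1` gives 500 nM. Compound 3 lies within the scatter of both other compounds, so the three values form a single group with no order among them.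

Compound 4 `CCCNC(=O)Nc1n[nH]c2c1CN(C(=O)C1CCN(C)CC1)C2(C)C` has not yet been measured. Its difference from compound 3 is propylamino in place of pyridin-4-yl on a carbonyl carbon. In words, this is propylamino in place of pyridin-4-yl on a carbonyl carbon, whose other neighbour is an amide-type nitrogen.

All three measured steps changed the group at this same carbonyl carbon. Going by the values given here, the closest precedent is a 1.4-fold higher number from compound 2 to compound 3 (0.15 log units; within the scatter), since it also exchanges pyridin-4-yl with an amino-linked group. The other two are a 1.3-fold higher number from compound 1 to compound 2 (0.11 log units; within the scatter) and a 1.9-fold higher number from compound 1 to compound 3 (0.27 log units; within the scatter). None of the three leaves the scatter, so no step beyond the scatter is expected in this assay. However, every measured compound carries a ring on this carbonyl carbon, and no measured compound shows what a chain without a ring does, so the range is kept wide.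

The expected change is small, an estimated 1.2-fold higher number from compound 3 to compound 4 (0.08 log units; within the scatter). For compound 4 the estimated value is 600 nM, with an expected range of 200 nM to 2000 nM.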

Compound 4, half-maximal inhibitory concentration: 650 nM
For compound 4 the middle estimate is 1.1-fold (0.03 log units) below the measured one, and the stated range covers the measured number.
By their numbers in this assay, from the lowest: compounds 1, 2, 3 and 4 (each within the scatter of the next, the first and the last beyond it).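

In this assay, going by these compounds alone, propylamino is the only group without a ring on this carbonyl carbon, yet it stays within the scatter of the two closest ring-bearing groups: the change gives a 1.3-fold higher number from compound 3 to compound 4 (0.11 log units; within the scatter) and the related exchange of 3-fluorophenyl for propyl on the amide-type nitrogen gives a 1.9-fold higher number from compound 2 to compound 4 (0.27 log units; within the scatter) on the same read-out. Among the compounds shown, an aromatic ring at this position is therefore not needed for a number in this range, although against naphthalen-2-yl the exchange gives a 2.4-fold higher number from compound 1 to compound 4 (0.38 log units; beyond the scatter) as the only step here beyond the scatter, and a modest one, while compound 2 and compound 3 remain within the scatter of both ends. Nothing available explains this step.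

Still open, from the compounds shown here alone, is whether a longer chain such as hexylamino, or a propylamino chain ending in a carboxylic acid or a dimethylamine, would stay in this range or move beyond the scatter. Also open, going by these compounds, is what the amide hydrogen of propylamino contributes, a question that a butyl group on the same carbonyl carbon would address.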